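A few compounds are considered here, and "the series" means these few. Any claim that something is new, unique, unknown or untested is made for them only; others in the source may bear on it.

Notes on the series. The shared core carries a saturated chain carbon bound to an aromatic carbon, and the group on that carbon is the only place that varies. Compound 1 `Cc1ccccc1Cc1nc2cc(O[C@H]3CC[C@@H](C(=O)O)CC3)ccc2n1C` gives 5400 nM in an assay on isolated protein for inhibition of Long-chain-fatty-acid--CoA ligase 1 (Mus musculus), read by mass spectrometry, with a stated time of 90 min, in the presence of a further agent that is not named here; on this read-out lower numbers stand for stronger inhibition and higher numbers for weaker inhibition. Compound 2 `Cc1ccc(Cc2nc3cc(O[C@H]4CC[C@@H](C(=O)O)CC4)ccc3n2C)cc1` gives 80 nM. Compound 3 `Cn1c(Cc2cccc(C(F)(F)F)c2)nc2cc(O[C@H]3CC[C@@H](C(=O)O)CC3)ccc21` gives 86 nM. The step of a 68-fold lower number from compound 1 to compound 2 (1.83 log units; beyond the scatter) and the step of a 63-fold lower number from compound 1 to compound 3 (1.80 log units; beyond the scatter) are both large, whereas a 1.1-fold higher number from compound 2 to compound 3 (0.03 log units; within the scatter) lies within the scatter. Compound 3 thus stands with compound 2 at the low end of the three numbers, far from compound 1.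

Compound 4 `Cn1c(Cc2cccnc2)nc2cc(O[C@H]3CC[C@@H](C(=O)O)CC3)ccc21` differs from compound 3 in one place: pyridin-3-yl in place of 3-(trifluoromethyl)phenyl on a saturated chain carbon bound to an aromatic carbon. Within the data shown here, no measured step exchanges a carbon-only ring for a ring with a hetero atom, and none removes a trifluoromethyl, so the three steps bear on the change only in showing that this position can move the number a long way. The change from a six-membered carbon ring with a trifluoromethyl to a smaller ring bearing one hydrogen-bond acceptor is expected to give a moderately higher number, with wide uncertainty. The expected step is a 4.1-fold higher number from compound 3 to compound 4 (0.61 log units; beyond the scatter). For compound 4 the estimate in this assay is 350 nM, ranging from 80 nM to 2000 nM.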

Compound 4, half-maximal inhibitory concentration: > 200000 nM
Compound 4 gave a limit, no number (the forecaster's own chance of this, stated with the estimate: 5%); middle value at least 570-fold (2.75 log units) away from the limit.
By their numbers in this assay, from the lowest: compounds 2 and 3 (each within the scatter of the next); then compound 1. At a limit, above all of these: compound 4.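

Compound 4 gives a limit of the assay and not a number: the limit of > 200000 nM in this assay, at which 1 of the 4 values shown sits. With an at least 2300-fold higher number from compound 3 to compound 4 (3.36 log units; beyond the scatter) and an at least 2500-fold higher number from compound 2 to compound 4 (3.39 log units; beyond the scatter), the two groups that could not be told apart in this assay both separate sharply from pyridin-3-yl, so the earlier hint that this position can move the number a long way becomes a much wider range. Even an at least 37-fold higher number from compound 1 to compound 4 (1.56 log units; beyond the scatter) lies beyond the scatter, which places pyridin-3-yl above 2-methylphenyl, until now the group with the highest number, and gives the first case among these compounds of a ring with a hetero atom on this saturated chain carbon, though it is a single example.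

From the compounds shown here alone, whether the step follows the ring nitrogen or the absence of a ring substituent stays open, and a plain phenyl or a pyridin-3-yl bearing a trifluoromethyl on this carbon would separate the two. Going by these compounds, all three steps end at a limit, and their full size stays open.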